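The source may report more compounds than this note shows. Statements on the series, on what has been measured and on what is new or still open speak of the compounds shown alone.

Three compounds share one core and differ only in what sits on one aromatic carbon of the methoxy-bearing ring. Compound 2 `COc1ccc(N(C)c2nc(C)nc3ccccc23)cc1` carries a hydrogen there, and in a functional assay on LoVo cells (Homo sapiens) for inhibition, read by MTT assay, with a stated time of 48 h (on this read-out higher numbers stand for weaker inhibition and lower numbers for stronger inhibition), compound 2 gives 8 nM. Compound 1 `COc1ccc(N(C)c2nc(C)nc3ccccc23)cc1C(=O)OCC[Se]C#N` carries an ester-linked chain ending in a selenocyanate, and compound 1 gives 2960 nM. Compound 3 `COc1ccc(N(C)c2nc(C)nc3ccccc23)cc1C(=O)OCCCC[Se]C#N` carries a longer chain of the same kind, and compound 3 gives 1080 nM. On these numbers compound 3 stands second highest of the three: its nearest neighbour is compound 1, with a 2.7-fold lower number from compound 1 to compound 3 (0.44 log units; beyond the scatter), and its furthest is compound 2, with a 140-fold higher number from compound 2 to compound 3 (2.13 log units; beyond the scatter).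

Compound 4 `COc1ccc(N(C)c2nc(C)nc3ccccc23)cc1[Se]C#N` keeps only the selenocyanate, now attached directly to the ring: a group of 3 heavy atoms (1 carbon, 1 nitrogen, 1 selenium; no ring) in place of a group of 10 heavy atoms (6 carbon, 1 nitrogen, 2 oxygen, 1 selenium; no ring), on an aromatic carbon. Among the measured compounds shown here, two measured steps bear on this change. Removing the whole shorter chain gave a 370-fold lower number from compound 1 to compound 2 (2.57 log units; beyond the scatter), a large gain, while the chain-length change a 2.7-fold lower number from compound 1 to compound 3 (0.44 log units; beyond the scatter) was only modest. Compound 4 sheds most of the chain but not all of it, so a large drop in this assay is expected, though probably not the full way back to compound 2. The expected step is a 7.2-fold lower number from compound 3 to compound 4 (0.86 log units; beyond the scatter). Compound 4 is therefore estimated at 150 nM, within a range of 30 nM to 800 nM.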

Compound 4, half-maximal inhibitory concentration: 73 nM
The estimate for compound 4 lay 2.1-fold (0.31 log units) above the measured number; low and high end bracket the measured number.
By their numbers in this assay, from the lowest: compound 2; then compound 4; then compound 3; then compound 1.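

Of the groups shown on this aromatic carbon, the selenocyanate attached directly to the ring sits closest to the bare hydrogen: this assay gives a 15-fold lower number from compound 3 to compound 4 (1.17 log units; beyond the scatter) and also a 41-fold lower number from compound 1 to compound 4 (1.61 log units; beyond the scatter) when the ester-linked chain is cut away, and both steps are large. Most of the weakening seen with the two ester-linked chains therefore goes with the ester and its chain and not with the selenocyanate alone, yet the selenocyanate still has a cost, as a 9.1-fold higher number from compound 2 to compound 4 (0.96 log units; beyond the scatter) shows, a modest step but one beyond the usual scatter. Nothing given here explains why either group weakens the read-out, so these steps stay a description of numbers and carry no reason.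

Going by these compounds, what stays open is whether any group on this carbon costs as much, which a plain nitrile or a methyl group there would help to show. An ethyl ester, with no selenium at all, would show how much of the weakening belongs to the ester itself and how much to the selenocyanate at the end of its chain.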